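The source may hold more compounds than are shown below. What is called first, only, known or untested is meant among the compounds shown, and "the series" means these compounds.

Working notes on the series. Compound 1 `CC(C)=CCC/C(C)=C/CC/C(C)=C/CSC[C@H](NC(=O)CCCCCN1CCCC1)C(=O)NC1CCCC1` is the reference point. Among the compounds with values here, in a functional assay on BXPC-3 cells (Homo sapiens) for cytotoxicity, read by fluorescence, with a stated time of 48 h (a lower number here means that less compound is needed, a higher number that more compound is needed for the effect), compound 1 gives 6800 nM, the only full number so far. Compound 2 `CC(C)=CCC/C(C)=C/CC/C(C)=C/CSC[C@H](NC(=O)CCCCCN1CCN(C)CC1)C(=O)NC1CCCC1` carries 4-methylpiperazin-1-yl in place of pyrrolidin-1-yl on a saturated chain carbon, five bonds along the chain from a carbonyl carbon. In this assay compound 2 reaches only the limit > 20000 nM. Within the data shown here, the step of an at least 2.9-fold higher number from compound 1 to compound 2 (0.46 log units; beyond the scatter) is the sole measured comparison, and its size rests on (the limit of > 20000 nM in this assay, at which 1 of the 2 values shown sits).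

Compound 3 `CC(C)=CCC/C(C)=C/CC/C(C)=C/CSC[C@H](NC(=O)CCCCCN1CCCC1)C(=O)N1CCCC1` is not yet measured. Its difference from compound 1 is pyrrolidin-1-yl in place of cyclopentylamino on a carbonyl carbon. Among the measured compounds shown here, no measured step touches the carbonyl carbon: the step from compound 1 to compound 2 alters the chain end, not the amide. Nothing in the series therefore sets a direction for this assay, and compound 3 is expected to sit near the level of compound 1, with a wide range. The estimated step is a 1.3-fold higher number from compound 1 to compound 3 (0.12 log units; within the scatter). Compound 3 is estimated at 9000 nM, from 3000 nM to 20000 nM, with a real chance that only a limit is returned.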

Compound 3, half-maximal effective concentration: 6500 nM
Estimate against measurement, compound 3: 1.4-fold (0.14 log units) above, within the range that was stated.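

The carbonyl carbon now has its first measured step: in this assay the exchange of cyclopentylamino for pyrrolidin-1-yl gives a 1.0-fold lower number from compound 1 to compound 3 (0.02 log units; within the scatter) and so compound 1 and compound 3 cannot be told apart. Within the data shown here, the hydrogen-bond donor counted on cyclopentylamino is absent from pyrrolidin-1-yl, so for this pair the amide hydrogen can go without a step beyond the scatter, whereas the chain end, the other place varied, gives an at least 2.9-fold higher number from compound 1 to compound 2 (0.46 log units; beyond the scatter) as the only such step. No measured property among these compounds bears on this result.

Among these compounds, open is how far the tolerance at the carbonyl carbon extends, since only two groups are compared there and both carry a five-membered ring: a morpholin-4-yl group, a piperidin-1-yl group or a carboxylic acid in this place could read differently. Also open, going by these compounds, is whether a longer chain or a primary amine at the chain end would give a lower number than compound 1 in this assay and whether any such result would carry over to the pyrrolidin-1-yl amide of compound 3.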